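The source may hold more compounds than are shown below. What is called first, only, known or untested is meant among the compounds shown, and "the series" means these compounds.

Compound 1 `CNc1nc(NCC(C)(C)C)cc(-c2ccccn2)n1` is the reference point of this pair. In a functional assay on HEK293 cells for agonist activity at G-protein coupled receptor 39 (Homo sapiens), read by inositol phosphate accumulation (on this read-out higher numbers stand for an effect only at larger amounts of compound and lower numbers for an effect already at smaller amounts), compound 1 gives 73 nM, the lowest of the two numbers in hand. Among the compounds with values here, compound 2 `c1ccc(-c2cc(NCC3CC3)ncn2)nc1` gives 22000 nM in this assay, a far higher number, well beyond the scatter; the two differ in more than one place, so their values show only that compound 1 lies far ahead. Compound 3 `CNc1nc(NCc2ccc(Cl)cc2Cl)cc(-c2ccccn2)n1` has not yet been measured. It departs from compound 1 by one change: 2,4-dichlorophenyl in place of tert-butyl on a saturated chain carbon bound to a nitrogen on an aromatic ring. Within the data shown here, no measured pair shows this exchange, so the size of its effect is unknown. Among the measured compounds shown here, with no such precedent, the step from compound 1 to compound 3 is expected to be small, a 1.2-fold lower number from compound 1 to compound 3 (0.09 log units; within the scatter), lying within or close to the scatter. Compound 3 is therefore estimated at 60 nM in this assay, within a range from 10 nM to 400 nM.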

Compound 3, half-maximal effective concentration: 0.8 nM
Beside the measured number, compound 3's estimate is 75-fold (1.88 log units) above it; the whole stated range lies above it.
By their numbers in this assay, from the lowest: compound 3; then compound 1; then compound 2.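

In this assay, putting 2,4-dichlorophenyl in place of tert-butyl on a saturated chain carbon bound to a nitrogen on an aromatic ring gives a 91-fold lower number from compound 1 to compound 3 (1.96 log units; beyond the scatter) and lies well beyond the scatter. The earlier pair differed in more than one place and could not isolate any single position, whereas this step shows that the number responds strongly to the group at this one. The tert-butyl group is therefore far from the limit of what this position allows, and an aromatic ring with two chlorine atoms is tolerated there and goes with a much lower number. No evidence at hand accounts for the size of this step.

The change brings in the ring and both chlorine atoms together, so their shares remain unseparated. A plain phenyl or a 4-chlorophenyl in the same place would divide them, while a methoxy group on the ring would test whether chlorine itself is needed.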